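Estimating the Clearance of Compound 4 from Compound 1

The source may hold more compounds than are shown below. What is called first, only, known or untested is meant among the compounds shown, and "the series" means these compounds.

Compound 1 `CCn1cc(-c2cc(C(O)(C(F)(F)F)C(F)(F)F)cnc2N2CCN(S(=O)(=O)c3ccc(N)nc3)CC2)cn1` was tested in an ADME assay (liver) for metabolic stability, with Liver microsome (Rattus norvegicus) as the target, using microsomes and NADPH, with a stated time of 30 min, tested at 1 uM (a higher number here means faster removal of the compound, a lower number slower removal), where compound 1 gives 194 mL.min-1.g-1. Of the three compounds measured, compound 1 stands second highest. Compound 2 `Cc1csc(-c2cc(C(O)(C(F)(F)F)C(F)(F)F)cnc2N2CCN(S(=O)(=O)c3ccc(N)nc3)CC2)c1` gives 399 mL.min-1.g-1, a step of a 2.1-fold higher number from compound 1 to compound 2 (0.31 log units; beyond the scatter). Compound 3 `Cc1nc2cc(-c3cc(C(O)(C(F)(F)F)C(F)(F)F)cnc3N3CCN(S(=O)(=O)c4ccc(N)nc4)CC3)ccc2o1` gives 99 mL.min-1.g-1, a step of a 2.0-fold lower number from compound 1 to compound 3 (0.29 log units; within the scatter). Compound 4 `Nc1ccc(S(=O)(=O)N2CCN(c3ncc(C(O)(C(F)(F)F)C(F)(F)F)cc3-c3ccc4c(c3)CC(=O)N4)CC2)cn1` has not yet been measured. It differs from compound 1 in one place: a group of 10 heavy atoms (8 carbon, 1 nitrogen, 1 oxygen; one five-membered non-aromatic ring with 1 hetero atom, one six-membered aromatic ring of carbon only) in place of a group of 7 heavy atoms (5 carbon, 2 nitrogen; one five-membered aromatic ring with 2 hetero atoms), on an aromatic carbon. For the measured compounds named here, the nearest precedent is compound 3, where a group holding a six-membered aromatic ring fused to a five-membered ring also replaced the 1-ethyl-1H-pyrazol-4-yl group and the result was a 2.0-fold lower number from compound 1 to compound 3 (0.29 log units; within the scatter). Compound 4 is therefore expected to give 130 mL.min-1.g-1, within a range of 60 mL.min-1.g-1 to 280 mL.min-1.g-1, an expected step of a 1.5-fold lower number from compound 1 to compound 4 (0.17 log units; within the scatter) that should remain within the scatter.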

Compound 4, intrinsic clearance in microsomes: 119 mL.min-1.g-1
The estimate for compound 4 lay 1.1-fold (0.04 log units) above the measured number; the measured number falls inside the stated range.
By their numbers in this assay, from the lowest: compounds 3, 4 and 1 (each within the scatter of the next); then compound 2.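

In this assay, a second group on this aromatic carbon with a six-membered aromatic ring fused to a five-membered ring, this time non-aromatic, stays within the scatter of the 1-ethyl-1H-pyrazol-4-yl group, with a 1.6-fold lower number from compound 1 to compound 4 (0.21 log units; within the scatter), and of the 2-methyl-1,3-benzoxazol-5-yl group, with a 1.2-fold higher number from compound 3 to compound 4 (0.08 log units; within the scatter). Only the 4-methylthiophen-2-yl group stands clearly apart, with a 3.4-fold lower number from compound 2 to compound 4 (0.53 log units; beyond the scatter). Nothing available here explains these steps. Open, on these data alone, is whether a plain phenyl group at this position would fall in the same range, and whether the five-membered ring is needed at all.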